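The compounds below may be only part of what the source reports. "The series", "measured", "known", "first", "only" and "open" are said of these compounds alone.

Working notes on the series. Compound 3 `CCCCCCCCCCc1cn(C[C@H](O)[C@H]2OC(=O)C(OCc3ccccc3)=C2OCc2ccccc2)nn1` gives 6750 nM in a functional assay on A549 cells (Homo sapiens) for antiproliferative activity, read by MTT assay, with a stated time of 72 h (on this read-out lower numbers stand for stronger inhibition and higher numbers for weaker inhibition), and stands as the lowest of the two numbers measured, with compound 1 `Cc1ccc(S(=O)(=O)NCc2cn(C[C@H](O)[C@H]3OC(=O)C(OCc4ccccc4)=C3OCc3ccccc3)nn2)cc1` nearest at 16800 nM. Compound 2 `O=C1O[C@H]([C@@H](O)Cn2cc(CCO)nn2)C(OCc2ccccc2)=C1OCc1ccccc1` returns only a limit, > 100000 nM. Compound 4 `CCCCc1cn(C[C@H](O)[C@H]2OC(=O)C(OCc3ccccc3)=C2OCc2ccccc2)nn1` differs from compound 3 by hydrogen in place of hexyl on a saturated chain carbon, four bonds along the chain from an aromatic carbon. The step that bears on it is an at least 14-fold lower number from compound 2 to compound 3 (1.17 log units; beyond the scatter), the long chain driving the number down; a 2.5-fold lower number from compound 1 to compound 3 (0.40 log units; beyond the scatter) points the same way. Shortening the chain is therefore expected to push the number back up, beyond the scatter but not to the limit. Compound 4 is estimated at 25000 nM (range 9000 nM to 70000 nM). The expected step is then a 3.7-fold higher number from compound 3 to compound 4 (0.57 log units; beyond the scatter).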

Compound 4, half-maximal inhibitory concentration: 28600 nM
Estimate against measurement, compound 4: 1.1-fold (0.06 log units) below, within the range that was stated.
By their numbers in this assay, from the lowest: compound 3; then compounds 1 and 4 (each within the scatter of the next). At a limit, above all of these: compound 2.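

Hydrogen in place of hexyl, four bonds along the chain from an aromatic carbon, gives a 4.2-fold higher number from compound 3 to compound 4 (0.63 log units; beyond the scatter), so a change in the alkyl chain alone moves the number beyond the scatter. Propyl in place of ((4-methylphenyl)sulfonyl)amino gives a 1.7-fold higher number from compound 1 to compound 4 (0.23 log units; within the scatter), so these two quite different groups cannot be told apart here. Ethyl in place of hydroxy gives an at least 3.4-fold lower number from compound 2 to compound 4 (0.54 log units; beyond the scatter), and the value of compound 2 is a limit, not a number: the limit of > 100000 nM in this assay, at which 1 of the 4 values shown sits.

As far as these compounds go, whether a longer chain than that of compound 3 lowers the number further remains open. So does whether an amine or a carboxylic acid at the chain end behaves like the hydroxy of compound 2.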